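The source may hold more compounds than are shown below. What is called first, only, known or untested is meant among the compounds shown, and "the series" means these compounds.

Within the data shown here, compound 2 `O=C(/C=C/c1cccc(NS(=O)(=O)c2cccc(Cl)c2)c1)c1nc2ccccc2[nH]1` gives 52.6% in an assay on isolated protein for inhibition of cathepsin S (Homo sapiens), read by fluorescence, with stated times of 15 min and 30 min, tested at 5 uM (on this read-out higher numbers stand for more inhibition at the one concentration tested (going by the name of the read-out) and lower numbers for less inhibition), and compound 1 `O=C(/C=C/c1cccc(NS(=O)(=O)c2ccccc2Cl)c1)c1nc2ccccc2[nH]1` gives 45.7%; the only step recorded, a number 6.9 percentage points higher from compound 1 to compound 2 (within the scatter), 3-chlorophenyl in place of 2-chlorophenyl on a sulfonyl sulfur, stays within the scatter, so the two stand level. Compound 3 `Cc1cccc(S(=O)(=O)Nc2cccc(/C=C/C(=O)c3nc4ccccc4[nH]3)c2)c1` differs from compound 2 by methyl in place of chloro on an aromatic carbon. Among the measured compounds shown here, no measured step replaces chloro with methyl, and the one step recorded in this assay did not move the number beyond the scatter, so nothing beyond the scatter is expected here either. Compound 3 is expected at 48%, with a range from 30% to 66%. The expected step is a number 4.6 percentage points lower from compound 2 to compound 3 (within the scatter).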

Compound 3, a percentage reported as inhibition, at one concentration (the size of the read-out at that concentration, not a potency): 50.1%
Estimate against measurement, compound 3: 2.1 percentage points below; the range from low to high includes it.
By their numbers in this assay, from the lowest: compounds 1, 3 and 2 (each within the scatter of the next).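

Among these compounds, the change from 3-chlorophenyl to 3-methylphenyl gives a number 2.5 percentage points lower from compound 2 to compound 3 (within the scatter) in this assay and so shows that methyl stands level with chloro at this position, which the earlier compounds, both carrying chloro, could not show. The change from 2-chlorophenyl to 3-methylphenyl gives a number 4.4 percentage points higher from compound 1 to compound 3 (within the scatter) and also leaves the compounds level. Nothing available accounts for this reading.

As far as these compounds go, whether an amine, a carboxylic acid or a longer chain at this position would move the number beyond the scatter remains open.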